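The compounds below may be only part of what the source reports. "The series", "measured", "known", "first", "only" and "open" are said of these compounds alone.

Compound 2 `CCN1CCN(c2cc(C)c3cc(NC(=O)c4ccccc4C)ccc3n2)CC1` has the highest number of the three measured compounds in a functional assay on SK-BR-3 cells (Homo sapiens) for antiproliferative activity, read by MTT assay, with a stated time of 72 h (on this read-out lower numbers stand for stronger inhibition and higher numbers for weaker inhibition), giving 29200 nM. Compound 3 `CCc1ccccc1C(=O)Nc1ccc2nc(N3CCN(CC)CC3)cc(C)c2c1` gives 23900 nM, and compound 1 `CCN(CC)CCNc1cc(C)c2cc(NC(=O)c3ccc(Cl)c(Cl)c3)ccc2n1` gives 3710 nM. Compound 4 `CCN1CCN(c2cc(C)c3cc(NC(=O)c4cccnc4)ccc3n2)CC1` differs from compound 2 in one place: pyridin-3-yl in place of 2-methylphenyl on a carbonyl carbon. Within the data shown here, only one measured step touches the same part of the molecule, the group on the carbonyl carbon: a 1.2-fold lower number from compound 2 to compound 3 (0.09 log units; within the scatter), so altering that group left the number essentially unchanged there. Among the measured compounds shown here, no measured step swaps a ring of carbon only for a ring with a nitrogen, so the evidence is thin. The step of a 1.0-fold higher number from compound 2 to compound 4 (0.01 log units; within the scatter) is expected to stay within the scatter. For compound 4 the estimate is 30000 nM, with a likely range from 10000 nM to 90000 nM.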

Compound 4, half-maximal inhibitory concentration: 10600 nM
Estimate against measurement, compound 4: 2.8-fold (0.45 log units) above; measured number inside the range.
By their numbers in this assay, from the lowest: compound 1; then compound 4; then compounds 3 and 2 (each within the scatter of the next).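

In this assay the group on the carbonyl carbon can move the number after all: pyridin-3-yl gives a 2.8-fold lower number from compound 2 to compound 4 (0.44 log units; beyond the scatter) and also a 2.3-fold lower number from compound 3 to compound 4 (0.35 log units; beyond the scatter) in a modest step beyond the scatter. The earlier change at this place, from 2-methylphenyl to 2-ethylphenyl, stayed within the scatter. No measurement here explains the shift. This swap both removes the alkyl group and puts nitrogen into the ring, so the two changes cannot be told apart. Plain phenyl on the carbonyl carbon would be needed to separate them.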